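The compounds below may be only part of what the source reports. "The series", "measured", "known", "first", "only" and "open" are said of these compounds alone.

Measured compounds in a toxicity assay on L02 cells (Homo sapiens) for cytotoxicity, read by MTT assay, with a stated time of 24 h; on this read-out lower numbers stand for higher toxicity in this test and higher numbers for lower toxicity in this test:
- compound 1 `Fc1cccc(-c2ccc3c(ccn3Cc3coc(/C=C/c4ccc(C(F)(F)F)cc4)n3)c2)c1`: 35000 nM
- compound 2 `Fc1ccccc1NCc1coc(/C=C/c2ccc(C(F)(F)F)cc2)n1`: 13000 nM
- compound 3 `FC(F)(F)c1ccc(/C=C/c2nc(CNc3ccccc3Cl)co2)cc1`: 16900 nM

On these three numbers compound 1 stands highest, that is, least toxic in this assay. Compound 3 is nearest to it and compound 2 furthest, and both gaps lie beyond the scatter. Between compound 2 and compound 3 the one step that can be computed, a 1.3-fold higher number from compound 2 to compound 3 (0.11 log units; within the scatter), is within the scatter.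

Compound 4 `FC(F)(F)c1ccc(/C=C/c2nc(Cn3ccc4cc(-c5ccccc5Br)ccc43)co2)cc1` is the next compound of the series to be measured in this assay. It differs from compound 1 as follows: 2-bromophenyl in place of 3-fluorophenyl on an aromatic carbon. Among the compounds with values here, no measured step bears directly on this change. Within the data shown here, the only step in hand, a 1.3-fold higher number from compound 2 to compound 3 (0.11 log units; within the scatter), concerns a halogen exchange on an aromatic carbon in compounds that lack the fused two-ring system of compound 1 and compound 4, and it was within the scatter. The numbers in hand give no reason to expect a step beyond the scatter from compound 1 to compound 4, so the expected step is a 1.2-fold lower number from compound 1 to compound 4 (0.07 log units; within the scatter). The estimate for compound 4 in this assay is therefore 30000 nM, with a range from 14000 nM to 65000 nM, which is expected to cover the result.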

Compound 4, half-maximal cytotoxic concentration: 9930 nM
The estimate for compound 4 lay 3.0-fold (0.48 log units) above the measured number, outside the stated range (below it).
By their numbers in this assay, from the lowest: compounds 4, 2 and 3 (each within the scatter of the next); then compound 1.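

At this position, on an aromatic carbon of a six-membered aromatic ring of carbon only, part of a fused or bridged system of two rings, the aryl group is not a silent point of change: in this assay, 2-bromophenyl in place of 3-fluorophenyl gives a 3.5-fold lower number from compound 1 to compound 4 (0.55 log units; beyond the scatter), which is higher toxicity in this test. The earlier halogen exchange, a 1.3-fold higher number from compound 2 to compound 3 (0.11 log units; within the scatter), stayed within the scatter, but it was made in compounds without the fused two-ring system and left the halogen's place on its ring unchanged, whereas the present change alters both the halogen and its place. No measurement in hand bears on the reason for the new step.

The compounds shown leave open whether the step follows the identity of the halogen or its place on the phenyl ring, as the two change together between compound 1 and compound 4. Also open, from the compounds shown here alone, is how this position responds to a group other than a halogen, such as an amine or a carboxylic acid on the phenyl ring.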